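From trifluoromethoxy to dimethylamino in a growth-inhibition series

The compounds below may be only part of what the source reports. "The series", "measured", "known", "first", "only" and "open" are said of these compounds alone.

In a functional assay on PC-3 cells (Homo sapiens) for inhibition, read by sulforhodamine B assay (a lower number here means a stronger inhibitor of growth, a higher number a weaker inhibitor of growth), compound 3 (`FC(F)(F)Oc1ccc(-c2ccc(-c3ccc(-c4nc5ccccc5[nH]4)cc3)cc2)cc1`) gives the highest of three numbers at 100000 nM, against compound 1 (`Cc1ccc2[nH]c(-c3ccc(-c4ccc(-c5ccc(N(C)C)cc5)cc4)cc3)nc2c1`) at 8120 nM and compound 2 (`COc1ccc(-c2ccc(-c3ccc(-c4nc5cc(C)ccc5[nH]4)cc3)cc2)cc1OC`) at 2560 nM. Compound 4 (`CN(C)c1ccc(-c2ccc(-c3ccc(-c4nc5ccccc5[nH]4)cc3)cc2)cc1`) differs from compound 3 by dimethylamino in place of trifluoromethoxy on an aromatic carbon. Within the data shown here, the one measured step touching this group, a 3.2-fold lower number from compound 1 to compound 2 (0.50 log units; beyond the scatter), was modest and starts from dimethylamino, so it bears only indirectly. Compound 1 is the closer guide, carrying dimethylamino and an added methyl on the core. A large step to a lower number is therefore expected in this assay, estimated as an 11-fold lower number from compound 3 to compound 4 (1.05 log units; beyond the scatter). For compound 4 the estimated value is 9000 nM, with an expected range of 3000 nM to 30000 nM.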

Compound 4, concentration for 50% growth inhibition: 100000 nM
For compound 4 the middle estimate is 11-fold (1.05 log units) below the measured one, and the stated range ends below it.
By their numbers in this assay, from the lowest: compound 2; then compound 1; then compounds 3 and 4 (each within the scatter of the next).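

In this assay the exchange of trifluoromethoxy for dimethylamino on the core without the methyl gives no change at the digits printed from compound 3 to compound 4 (within the scatter) and so leaves the number where it stood. Hydrogen in place of methyl on an aromatic carbon, with dimethylamino kept, gives a 12-fold higher number from compound 1 to compound 4 (1.09 log units; beyond the scatter) and is the only difference within that pair, so the core methyl, not the dimethylamino group alone, separates these two numbers. As far as these compounds go, whether the same methyl would lower the number of compound 3, and how a carboxylic acid or a morpholine would behave in place of dimethylamino, stays open. No measurement at hand explains either step.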